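This account rests on a few compounds, and the source may have more. Where it says the series, first, only, none or still open, it means among the compounds named here.

For the measured compounds named here, in a functional assay on HepG2 cells (Homo sapiens) for antiproliferative activity, read by MTT assay, with a stated time of 48 h (on this read-out higher numbers stand for weaker inhibition of growth and lower numbers for stronger inhibition of growth), compound 2 `CCOC(=O)N1N=C(c2cccc(O)c2)CC1c1cc(OC)c(OC)c(OC)c1` gives 1790 nM as the only actual number so far. Compound 1 `COc1ccc(C2=NN(C(=O)OCc3ccccc3)C(c3cc(OC)c(OC)c(OC)c3)C2)cc1` gives > 10000 nM and this is a limit of the assay, not a number. Compound 3 `COc1cc(C2CC(c3cccc(O)c3)=NN2C(=O)OCc2ccccc2)cc(OC)c1OC` is the next step, with the change (phenyl in place of methyl on a saturated chain carbon bound to an oxygen next to a carbonyl group), so that ethoxycarbonyl turns into benzyloxycarbonyl. Going by the values given here, no measured step in this assay covers this change, so the expectation rests on little. Compound 1 also bears benzyloxycarbonyl and is known only by the limit > 10000 nM so the expected direction is towards weaker inhibition of growth. The estimated step of a 2.2-fold higher number from compound 2 to compound 3 (0.35 log units; beyond the scatter) is expected to be modest, only a little beyond the scatter. Compound 3 is estimated at 4000 nM with an expected range of 1200 nM to 10000 nM for the measurement.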

Compound 3, concentration for 50% growth inhibition: > 10000 nM
Compound 3: no number, only a limit; the forecaster's own chance of this, stated with the estimate: 25%; at least 2.5-fold (0.39 log units) between middle value and limit.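

In this assay, for the compounds shown here, the change from ethoxycarbonyl to benzyloxycarbonyl gives an at least 5.5-fold higher number from compound 2 to compound 3 (0.74 log units; beyond the scatter), the first readable step at this position, with the 3-hydroxyphenyl group held constant. Both compounds shown with benzyloxycarbonyl, compound 1 and compound 3, sit at the limit, while compound 2 with ethoxycarbonyl is the only one to give an actual number, so on these compounds benzyloxycarbonyl is not tolerated with either aryl group. The step between compound 1 and compound 3 cannot be read, and the full size of the loss stays open: the limit of > 10000 nM in this assay, at which 2 of the 3 values shown sit.

Open, as far as these compounds go, is how methoxycarbonyl or a longer chain such as butoxycarbonyl would compare with ethoxycarbonyl at this position. Also open, from the compounds shown here alone, is what 4-methoxyphenyl in place of 3-hydroxyphenyl does when ethoxycarbonyl is kept.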